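Working notes: aryl exchange on the shared core

The compounds below may be only part of what the source reports. "The series", "measured", "known", "first", "only" and "open" are said of these compounds alone.

- compound 1 `Cc1ccccc1Nc1nc(Nc2ccc(N3CCN(C)CC3)cn2)ncc1Cl` at 5210 nM
- compound 2 `CC(C)c1cccc(Nc2nc(Nc3ccc(N4CCN(C)CC4)cn3)ncc2Cl)c1` at 8640 nM

In a functional assay on MCF7 cells (Homo sapiens) for inhibition, read by CCK-8 assay, with a stated time of 48 h (on this read-out higher numbers stand for weaker inhibition of growth and lower numbers for stronger inhibition of growth), compound 2 at 8640 nM sits within the scatter of compound 1. Next comes compound 3 `CN1CCN(c2ccc(Nc3ncc(Cl)c(Nc4ccc(C(C)(C)C)cc4)n3)nc2)CC1` with 4-(tert-butyl)phenyl in place of 3-isopropylphenyl on a nitrogen on an aromatic ring. Within the data shown here, the one measured step bearing on this, also an exchange of the group on that nitrogen, is a 1.7-fold higher number from compound 1 to compound 2 (0.22 log units; within the scatter) and lies within the scatter. No step beyond the scatter is therefore expected in this assay for this change. The estimated step is a 1.1-fold lower number from compound 2 to compound 3 (0.03 log units; within the scatter) in size. Compound 3 is expected at 8000 nM within an estimated range of 3000 nM to 20000 nM for now.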

Compound 3, concentration for 50% growth inhibition: 12600 nM
The estimate for compound 3 lay 1.6-fold (0.20 log units) below the measured number; measured number inside the range.
By their numbers in this assay, from the lowest: compounds 1, 2 and 3 (each within the scatter of the next, the first and the last beyond it).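

In this assay, among these compounds, the exchange on the nitrogen gives a 1.5-fold higher number from compound 2 to compound 3 (0.16 log units; within the scatter) and so stays within the scatter, whereas a 2.4-fold higher number from compound 1 to compound 3 (0.38 log units; beyond the scatter) is the first step to pass beyond it. Among the three aryl groups on this nitrogen, only 2-methylphenyl and 4-(tert-butyl)phenyl are separated by the assay. No measurement at hand accounts for this separation.

Still open, as far as these compounds go, is whether a phenyl group carrying an amine or a carboxylic acid would give a lower number than compound 1. The same holds for a cyclohexyl group on this nitrogen.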